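The compounds below may be only part of what the source reports. "The series", "measured", "known", "first", "only" and "open" are said of these compounds alone.

Compound 1, `COc1ccc(/C=C\c2cc(OC)c(OC)c(OC)c2)cc1OCc1ccc(CN2CCCCC2C(=O)O)cc1`, was examined in an ADME assay on NCM460 cells (Homo sapiens) for cytotoxicity, read by CCK-8 assay, with a stated time of 48 h; on this read-out higher numbers stand for weaker inhibition and lower numbers for stronger inhibition. In this assay compound 1 gives > 50000 nM, which is a limit of the assay and not a number; the relevant fact is the limit of > 50000 nM in this assay, at which 1 of the 3 values shown sits. Two close relatives supply numbers. Compound 2, `COc1ccc(/C=C\c2cc(OC)c(OC)c(OC)c2)cc1OCc1ccc(CNCCO)cc1`, gives in this assay 39000 nM, and compound 3, `COc1ccc(/C=C\c2cc(OC)c(OC)c(OC)c2)cc1OCc1ccc(CNCCN(C)C)cc1`, gives 35000 nM. The measured steps from compound 1 are an at least 1.2-fold lower number from compound 1 to compound 2 (0.10 log units; that floor lies within the scatter) and an at least 1.4-fold lower number from compound 1 to compound 3 (0.15 log units; that floor lies within the scatter), while between the two relatives the step is a 1.1-fold lower number from compound 2 to compound 3 (0.05 log units; within the scatter). Every step shown, then, sits within the scatter, and compound 1 is known only as a limit.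

Compound 4, `COc1ccc(/C=C\c2cc(OC)c(OC)c(OC)c2)cc1OCc1ccc(CO)cc1`, is the next step from compound 1. The change is hydroxy in place of 2-carboxypiperidin-1-yl on a saturated chain carbon bound to an aromatic carbon, that is, hydroxymethyl in place of (2-carboxypiperidin-1-yl)methyl. The two steps from compound 1 already shown bear on it directly, and both reach only floors that lie within the scatter, so no step beyond the scatter is expected in this assay in either direction. Compound 4 is therefore expected to give about 45000 nM, with a range from 20000 nM to 100000 nM. The step that this estimate means is expected to be an at least 1.1-fold lower number from compound 1 to compound 4 (0.04 log units; that floor lies within the scatter).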

Compound 4, half-maximal inhibitory concentration: > 50000 nM
Compound 4: only a limit was reported; the forecaster's own chance of this, stated with the estimate: 45%; middle value at least 1.1-fold (0.04 log units) from the limit.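

With hydroxy on the saturated chain carbon bound to an aromatic carbon, the nitrogen and the whole 2-carboxypiperidin-1-yl group are gone, yet compound 4 in this assay stays at a limit of the assay, as compound 1 does: the limit of > 50000 nM in this assay, at which 2 of the 4 values shown sit.

So a single oxygen at this place and a group of 9 heavy atoms end at the same limit, and the two amines do not stand apart from the hydroxy compound, with an at least 1.4-fold higher number from compound 3 to compound 4 (0.15 log units; that floor lies within the scatter) and an at least 1.2-fold higher number from compound 2 to compound 4 (0.10 log units; that floor lies within the scatter), both floors lying within the scatter. The step between compound 1 and compound 4 cannot be read, as both values are limits.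

The compounds shown leave open how far past the limit compound 1 and compound 4 actually lie, and whether any group at this place moves the number beyond the scatter. A primary amine or a longer chain ending in a carboxylic acid on the same chain carbon would test whether this change matters at all in this assay.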